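Replacing a carboxyphenyl sulfone with a fluorophenyl sulfonamide

This account rests on a few compounds, and the source may have more. Where it says the series, first, only, none or still open, it means among the compounds named here.

Compound 1: `Cn1c(=O)c(S(=O)(=O)c2ccc(C(=O)O)cc2)cc2cnc(Nc3ccc4[nH]ccc4c3)nc21` — 5000 nM
Compound 2: `CCCn1c(=O)c(S(=O)(=O)c2ccc(F)cc2F)cc2cnc(Nc3ccc4[nH]ccc4c3)nc21` — 1000 nM

Of the compounds shown here, two built on the same core have been tested in a functional assay on K562 cells (Homo sapiens) for inhibition, read by trypan blue exclusion, with a stated time of 72 h; a lower number here means a stronger inhibitor, a higher number a weaker inhibitor. Compound 1 gives 5000 nM, the higher of the two numbers, so it is the weaker inhibitor of the pair. The two structures differ in several places. In this assay compound 2 gives 1000 nM, a gap beyond the usual scatter.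

Compound 3 is `Cn1c(=O)c(S(=O)(=O)Nc2ccc(F)cc2)cc2cnc(Nc3ccc4[nH]ccc4c3)nc21`. Compared with compound 1 it carries (4-fluorophenyl)amino in place of 4-carboxyphenyl on a sulfonyl sulfur. No step in this assay between measured compounds has been recorded for a change of this kind, so no shown step can guide a prediction. Compound 3 is expected to show a modest improvement, a step of a 2.0-fold lower number from compound 1 to compound 3 (0.30 log units; within the scatter), with wide uncertainty. The estimate for compound 3 in this assay is 2500 nM, between 600 nM and 10000 nM.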

Compound 3, half-maximal inhibitory concentration: 5000 nM
Compound 3: middle estimate off by 2.0-fold (0.30 log units), on the low side; low and high end bracket the measured number.
By their numbers in this assay, from the lowest: compound 2; then compounds 1 and 3 (each within the scatter of the next).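

In this assay, putting (4-fluorophenyl)amino in place of 4-carboxyphenyl on the sulfonyl sulfur gives no change at the digits printed from compound 1 to compound 3 (within the scatter). Within the data shown here, this is the first comparison here in which only one place differs, and it shows that this position accepts the swap with no measurable change: the carboxylic acid can leave without the number moving. Nothing shown explains why the two groups read alike.

Compound 2 differs from compound 1 and compound 3 in several places, so its lower number cannot be traced to any single group. Going by these compounds, it also stays open whether a simple amine, or a phenylamino group without the fluorine, on the sulfonyl sulfur would shift the number.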